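Swapping the Ether Chain for an Aryl Ring

The source may report more compounds than this note shows. Statements on the series, on what has been measured and on what is new or still open speak of the compounds shown alone.

In an assay on HEK cells for antagonist activity at transient receptor potential cation channel subfamily V member 1 (Homo sapiens), read by FLIPR (on this read-out lower numbers stand for stronger inhibition and higher numbers for weaker inhibition), compound 3 `O=C(NCc1ccc(C(F)(F)F)nc1OCC1CCCC1)Nc1cccc2[nH]c(=O)ccc12` stands at 2.18 nM, a number that its two measured companions sit close to: compound 2 `CC(C)COc1nc(C(F)(F)F)ccc1CNC(=O)Nc1cccc2[nH]c(=O)ccc12` gives 2.6 nM and compound 1 `CCCCCOc1nc(C(F)(F)F)ccc1CNC(=O)Nc1cccc2[nH]c(=O)ccc12` gives 2.72 nM. The three steps, a 1.0-fold lower number from compound 1 to compound 2 (0.02 log units; within the scatter), a 1.2-fold lower number from compound 1 to compound 3 (0.10 log units; within the scatter) and a 1.2-fold lower number from compound 2 to compound 3 (0.08 log units; within the scatter), alter only the saturated chain carbon bound to the ether oxygen. Compound 4 `CC(C)c1cccc(-c2nc(C(F)(F)F)ccc2CNC(=O)Nc2cccc3[nH]c(=O)ccc23)c1` makes a different move: 3-isopropylphenyl in place of cyclopentylmethoxy on an aromatic carbon. Going by the values given here, no measured step touches a change of this kind, so the earlier steps show only that the ether chain tolerated variation; they say nothing about removing the oxygen altogether. A weakening is therefore expected from compound 3 to compound 4, a 5.5-fold higher number from compound 3 to compound 4 (0.74 log units; beyond the scatter), with wide uncertainty. Compound 4 is estimated at 12 nM, in a range from 1.5 nM to 90 nM.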

Compound 4, half-maximal inhibitory concentration: 1.35 nM
For compound 4 the middle estimate is 8.9-fold (0.95 log units) above the measured one; the whole stated range lies above it.
By their numbers in this assay, from the lowest: compounds 4, 3, 2 and 1 (each within the scatter of the next).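

In this assay the move to 3-isopropylphenyl on this aromatic carbon next to the ring nitrogen gives a 1.6-fold lower number from compound 3 to compound 4 (0.21 log units; within the scatter) and a 1.9-fold lower number from compound 2 to compound 4 (0.28 log units; within the scatter) and a 2.0-fold lower number from compound 1 to compound 4 (0.30 log units; within the scatter) so all three steps stay within the scatter. Among these four compounds, then, the ether oxygen is not needed for a number in this range, and an aromatic ring of carbon only serves here as well as the saturated chains do. On these data alone, whether the isopropyl on the new ring matters stays open, as does how an amine on this carbon would compare. Nothing measured here explains this tolerance.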